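Replacing a Methoxybenzyl Ether with an Isopropoxybenzyl Ether

A few compounds are considered here, and "the series" means these few. Any claim that something is new, unique, unknown or untested is made for them only; others in the source may bear on it.

Compound 1 `COc1cccc(OC)c1OCCNCCOc1ccccc1OCc1ccccc1Cl` gives 7.52 in a functional assay on spleen for antagonist activity at Alpha-1B adrenergic receptor (Rattus norvegicus); a lower number here means a less potent compound, a higher number a more potent compound, by a factor of ten per unit of this negative logarithm.
Compound 2 `COc1cccc(OC)c1OCCNCCOc1ccccc1OCc1ccc([N+](=O)[O-])cc1` gives 9.02 in this assay.
Compound 3 `COc1ccccc1COc1ccccc1OCCNCCOc1c(OC)cccc1OC` gives 8.13 in this assay.

Compound 3 stands second highest of these three numbers: it lies above compound 1 and below compound 2, and both gaps are beyond the usual scatter. Compound 4 `COc1cccc(OC)c1OCCNCCOc1ccccc1OCc1ccc(OC(C)C)cc1` differs from compound 3 in one place: 4-isopropoxyphenyl in place of 2-methoxyphenyl on a saturated chain carbon bound to an oxygen on an aromatic ring.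

Within the data shown here, two measured steps bear on this change. The step of a number 0.89 log units lower from compound 2 to compound 3 (beyond the scatter) involves the same 2-methoxyphenyl group at the same place, and the step of a number 1.50 log units higher from compound 1 to compound 2 (beyond the scatter) concerns another exchange at that place. In both, the compound carrying a 4-nitrophenyl was the more potent partner. Among the measured compounds shown here, compound 4 carries a 4-isopropoxyphenyl instead, a group that none of the measured compounds has, so the expectation rests on an analogy rather than a direct precedent. The step from compound 3 to compound 4 is expected to be modest and upward, a number 0.37 log units higher from compound 3 to compound 4 (beyond the scatter). Compound 4 is therefore expected to give 8.5, in a range from 7.8 to 9.2.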

Compound 4, negative logarithm of the antagonist equilibrium constant: 8.62
Beside the measured number, compound 4's estimate is 0.12 log units below it, and the stated range covers the measured number.
By their numbers in this assay, from the lowest: compound 1; then compound 3; then compound 4; then compound 2.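

In this assay a high number at this place does not depend on a nitro group: putting in 4-isopropoxyphenyl gives a number 0.49 log units higher from compound 3 to compound 4 (beyond the scatter) and a number 1.10 log units higher from compound 1 to compound 4 (beyond the scatter) in the same direction. The nitro group still keeps the lead, as isopropoxy in place of nitro gives a number 0.40 log units lower from compound 2 to compound 4 (beyond the scatter) and leaves 4-nitrophenyl and 4-isopropoxyphenyl both above 2-methoxyphenyl and 2-chlorophenyl among these four compounds. No measurement given here explains these differences.

The step from 2-methoxyphenyl to 4-isopropoxyphenyl changes both where the ether sits on the ring and how large it is, and telling those two apart would take 4-methoxyphenyl or 2-isopropoxyphenyl at this place. On these data alone, how a 4-aminophenyl or a 4-carboxyphenyl group would fare here also stays open.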